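A few compounds are considered here, and "the series" means these few. Any claim that something is new, unique, unknown or untested is made for them only; others in the source may bear on it.

Three compounds of the series share the core of compound 1 `Cn1c(-c2ccc(NC(=O)CCl)cc2)nc(-c2ccccc2)c1-c1ccccc1`; in a functional assay on HT-29 cells (Homo sapiens) for cytotoxicity, read by MTT assay, with a stated time of 24 h, tested at 16 ug/mL (a lower number here means a weaker effect, a higher number a stronger effect of the compound at the concentration tested), compound 1 gives 23.7%. Compound 2 `Cn1c(-c2ccc(NC(=O)CSc3nc4cc(Cl)ccc4o3)cc2)nc(-c2ccccc2)c1-c1ccccc1` gives 42.5%, and compound 3 `Cn1c(-c2ccc(NC(=O)CSc3nc4ccccc4s3)cc2)nc(-c2ccccc2)c1-c1ccccc1` gives 47.2%. Compound 2 stands second highest of the three numbers, with compound 3 nearest (a number 4.7 percentage points higher from compound 2 to compound 3 (within the scatter)) and compound 1 furthest (a number 18.8 percentage points higher from compound 1 to compound 2 (beyond the scatter)). Compound 4 `Cc1nnc(SCC(=O)Nc2ccc(-c3nc(-c4ccccc4)c(-c4ccccc4)n3C)cc2)s1` is not yet measured; it differs from compound 2 as follows: 5-methyl-1,3,4-thiadiazol-2-yl in place of 5-chloro-1,3-benzoxazol-2-yl on a sulfur. Going by the values given here, the one step that bears directly on exchanging the group on the sulfur is a number 4.7 percentage points higher from compound 2 to compound 3 (within the scatter); the steps of a number 18.8 percentage points higher from compound 1 to compound 2 (beyond the scatter) and a number 23.5 percentage points higher from compound 1 to compound 3 (beyond the scatter) only show that either sulfanyl group in place of chloro gives a higher number. A step within the scatter is therefore expected, a number 2.5 percentage points lower from compound 2 to compound 4 (within the scatter). Compound 4 is estimated at 40%, with a range from 27% to 53%.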

Compound 4, a percentage reported as activity, at one concentration (the size of the read-out at that concentration, not a potency): 83.3%
Compound 4: middle estimate off by 43.3 percentage points, on the low side; the measured number lies above the stated range.
By their numbers in this assay, from the lowest: compound 1; then compounds 2 and 3 (each within the scatter of the next); then compound 4.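

At the sulfur, the group attached is far from interchangeable: in this assay, 5-methyl-1,3,4-thiadiazol-2-yl gives a number 40.8 percentage points higher from compound 2 to compound 4 (beyond the scatter) and a number 36.1 percentage points higher from compound 3 to compound 4 (beyond the scatter), although compound 2 and compound 3 lie within the scatter of each other. Going by these compounds alone, replacing chloro on the saturated chain carbon can therefore give much more than the earlier steps showed, with a number 59.6 percentage points higher from compound 1 to compound 4 (beyond the scatter). The largest number in this set comes with the smaller entering group, which has one aromatic ring rather than two.

Nothing measured here explains this step. From the compounds shown here alone, whether the step follows the single ring, its hetero atoms or the methyl remains open, as does the effect of an amine in place of that methyl.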